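Swapping the aromatic group of compound 2

A few compounds are considered here, and "the series" means these few. Any claim that something is new, unique, unknown or untested is made for them only; others in the source may bear on it.

Values in a functional assay on KB cells (Homo sapiens) for antiproliferative activity, read by sulforhodamine B assay, with a stated time of 3 days (on this read-out higher numbers stand for an effect only at larger amounts of compound and lower numbers for an effect already at smaller amounts), follow.
- Compound 1 `CCCc1ccc(-c2cc(=O)c3c(o2)C(CC)(CC)C(=O)C(CC)=C3O)cc1` gives > 53 uM, which is a limit.
- Compound 2 `CCC1=C(O)c2c(oc(-c3cc(C)c(C)cc3C)cc2=O)C(CC)(CC)C1=O` gives 8.2 uM.

Among the compounds with values here, compound 2 holds the only actual number so far. Compound 3 `CCC1=C(O)c2c(oc(-c3cc(C)c(O)c(C)c3)cc2=O)C(CC)(CC)C1=O` carries 4-hydroxy-3,5-dimethylphenyl in place of 2,4,5-trimethylphenyl (4-hydroxy-3,5-dimethylphenyl in place of 2,4,5-trimethylphenyl on an aromatic carbon). Within the data shown here, the one measured step, an at least 6.4-fold lower number from compound 1 to compound 2 (0.81 log units; beyond the scatter), changes the aromatic group at the same place, and its size rests on a limit (the limit of > 53 uM in this assay, at which 1 of the 2 values shown sits). That step shows that this place can matter, so a modest move toward higher numbers in this assay is expected. The expected change is a 2.4-fold higher number from compound 2 to compound 3 (0.39 log units; beyond the scatter). For compound 3 the estimate is 20 uM, with an expected range from 5 uM to 70 uM.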

Compound 3, concentration for half-maximal effect: 18.3 uM
For compound 3 the middle estimate is 1.1-fold (0.04 log units) above the measured one, within the range that was stated.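

Putting 4-hydroxy-3,5-dimethylphenyl in place of 2,4,5-trimethylphenyl brings a hydrogen-bond donor and acceptor to this place, and the change in the number stays modest (a 2.2-fold higher number from compound 2 to compound 3 (0.35 log units; beyond the scatter)). The same group still compares well with 4-propylphenyl (an at least 2.8-fold lower number from compound 1 to compound 3 (0.46 log units; beyond the scatter)). The size of that second step is only a bound: the limit of > 53 uM in this assay, at which 1 of the 3 values shown sits. The compounds shown leave open how an amine or a carboxylic acid would fare on this aromatic ring. They also do not separate the hydroxy group from the moved methyl groups.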